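The source may hold more compounds than are shown below. What is called first, only, known or untested is meant among the compounds shown, and "the series" means these compounds.

Measured so far in a functional assay on SNB-19 cells (Homo sapiens) for cytotoxicity, read by sulforhodamine B assay, with a stated time of 48 h; a higher number here means a weaker inhibitor of growth, a lower number a stronger inhibitor of growth:
Compound 1 `ClCc1ccc(Cn2cnc3c(Cl)ncnc32)cc1` — compound 1 gives 3630 nM
Compound 2 `ClCc1ccccc1Cn1cnc2c(Cl)ncnc21` — compound 2 gives 5370 nM
Compound 3 `ClCc1cccc(Cn2cnc3c(Cl)ncnc32)c1` — compound 3 gives 2630 nM

Three compounds share one core and differ only in where the chloromethyl-bearing arm sits on the benzyl ring. Compound 3 has the lowest number of the three in this assay. Compound 1 sits close to it, within the usual scatter, so no order can be read between those two. Compound 2 has a higher number than compound 3, and that gap lies beyond the scatter.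

Compound 4 `ClCc1cccc(Cn2cnc3c(Cl)nc(Cl)nc32)c1` keeps everything of compound 3 and adds one atom: chloro in place of hydrogen on an aromatic carbon. Within the data shown here, no pair of measured compounds shows what such a chloro between two ring nitrogen atoms does here, so the size of the step can only be guessed. Nothing in the three measured compounds points to a large move in either direction; a small change, most likely a number a little lower than that of compound 3 but possibly within the scatter, is what is expected.

Compound 4 is therefore estimated at 2000 nM in this assay, with a range from 700 nM to 6000 nM. That estimate means an expected step of a 1.3-fold lower number from compound 3 to compound 4 (0.12 log units; within the scatter).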

Compound 4, concentration for 50% growth inhibition: 1950 nM
For compound 4 the middle estimate is 1.0-fold (0.01 log units) above the measured one; the range from low to high includes it.
By their numbers in this assay, from the lowest: compounds 4, 3, 1 and 2 (each within the scatter of the next, the first and the last beyond it).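

In this assay, chloro in place of hydrogen on an aromatic carbon, between two ring nitrogen atoms, gives a 1.3-fold lower number from compound 3 to compound 4 (0.13 log units; within the scatter). Among these compounds, this is the first pair that differs at this position rather than in where the chloromethyl-bearing arm sits, and it shows that this one added chlorine atom can be carried here without a shift that can be told from the usual scatter, so compound 3 and compound 4 cannot be put in order. Nothing measured for these compounds explains this result.

The compounds shown leave open whether a larger or differently built group at the same carbon, such as an amine or a methoxy group, would move the number beyond the scatter, since hydrogen and chloro are the only two substituents seen there. They also leave open whether the same chloro would read alike on the other two arrangements of the chloromethyl-bearing arm, as the position has been examined only with the arrangement found in compound 3.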